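One More Chain Carbon: Does Half-Life Hold?

The compounds below may be only part of what the source reports. "The series", "measured", "known", "first", "only" and "open" are said of these compounds alone.

Of the compounds shown here, three have been tested in an ADME assay for metabolic stability, read by HPLC, at pH 7.4; a lower number here means that the compound disappears faster, a higher number that the compound lasts longer: compound 1 `CCCCCCCCNC(=O)Oc1ccc(Cl)cc1C(=O)Nc1cccc(Cl)c1`, compound 2 `CCCCCCCCCNC(=O)Oc1ccc(Cl)cc1C(=O)Nc1cccc(Cl)c1` and compound 3 `CCCCCCCCNC(=O)Oc1ccc(Cl)cc1C(=O)Nc1ccc(Cl)cc1`. Compound 1 gives 43 h, compound 2 gives 43 h, and compound 3 gives 43 h. The change from compound 1 to compound 2 is methyl in place of hydrogen on a saturated chain carbon, eight bonds along the chain from an amide-type nitrogen; in this assay it gave no change at the digits printed from compound 1 to compound 2 (within the scatter). The two cores differ as 4-chlorophenyl in place of 3-chlorophenyl on an amide-type nitrogen, a change that gave no change at the digits printed from compound 1 to compound 3 (within the scatter). Compound 4 `CCCCCCCCCNC(=O)Oc1ccc(Cl)cc1C(=O)Nc1ccc(Cl)cc1` has not yet been measured; it carries the same change from compound 3, namely (methyl in place of hydrogen on a saturated chain carbon, eight bonds along the chain from an amide-type nitrogen). Compound 4 is expected to show no change at the digits printed from compound 3 to compound 4 (within the scatter), because the same change earlier gave no change at the digits printed from compound 1 to compound 2 (within the scatter). Compound 4 is therefore estimated at 43 h, with an expected range from 30 h to 62 h.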

Compound 4, half-life: 43 h
Beside the measured number, compound 4's estimate shows no gap at the digits printed, and the stated range covers the measured number.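

Among the compounds shown here, the methyl change carried from one core to the other in this assay, giving no change at the digits printed from compound 3 to compound 4 (within the scatter): the same change on two cores in this assay, no change at the digits printed (within the scatter) from compound 1 to compound 2 and no change at the digits printed (within the scatter) from compound 3 to compound 4, 1.0-fold (0.00 log units) apart, within the scatter of two such steps The change to 4-chlorophenyl, which gave no change at the digits printed from compound 2 to compound 4 (within the scatter), also held on both cores: the same change on two cores in this assay, no change at the digits printed (within the scatter) from compound 1 to compound 3 and no change at the digits printed (within the scatter) from compound 2 to compound 4, 1.0-fold (0.00 log units) apart, within the scatter of two such steps This shows only that neither change moved the half-life on these two cores; it does not show that a step of real size would carry across in the same way, and it does not explain why the half-life stays level.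

Still open, on these data alone, is how a much longer chain, an amine or a carboxylic acid would fare. Also open, as far as these compounds go, is whether such a change would carry from one core to another as these two did.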